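The source may hold more compounds than are shown below. What is called first, only, known or untested is meant among the compounds shown, and "the series" means these compounds.

Measured so far in an ADME assay on HepG2 2.2.15 cells (Homo sapiens) for cytotoxicity, read by MTT assay, with a stated time of 9 days; on this read-out lower numbers stand for higher toxicity in this test and higher numbers for lower toxicity in this test:

compound 1, `CCOC(=O)c1cc2c(Cn3ccnc3)c(O)c(OC)cc2nc1CSc1ccc(F)c(F)c1`: compound 1 gives 133 uM
compound 2, `CCOC(=O)c1cc2c(Cn3ccnc3)c(O)c(OC)cc2nc1CSc1ccc(F)cc1`: compound 2 gives 202 uM
compound 3, `CCOC(=O)c1cc2c(Cn3ccnc3)c(O)c(OC)cc2nc1C[S+]([O-])c1ccc(F)cc1`: compound 3 gives 160 uM

Two cores are present. Compound 3 differs from compound 2 in that (a group of 9 heavy atoms (6 carbon, 1 oxygen, 1 fluorine, 1 sulfur; one six-membered aromatic ring of carbon only) in place of a group of 8 heavy atoms (6 carbon, 1 fluorine, 1 sulfur; one six-membered aromatic ring of carbon only), on a saturated chain carbon bound to an aromatic carbon); this core change gave a 1.3-fold lower number from compound 2 to compound 3 (0.10 log units; within the scatter). Between compound 1 and compound 3 the cores also differ, and the step there was a 1.2-fold higher number from compound 1 to compound 3 (0.08 log units; within the scatter). All three numbers sit close together in this assay.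

Within the core of compound 2, the change from compound 2 to compound 1 is fluoro in place of hydrogen on an aromatic carbon. The step it produced was a 1.5-fold lower number from compound 2 to compound 1 (0.18 log units; within the scatter).

Compound 4, `CCOC(=O)c1cc2c(Cn3ccnc3)c(O)c(OC)cc2nc1C[S+]([O-])c1ccc(F)c(F)c1`, is not yet measured. It stands to compound 3 as compound 1 stands to compound 2: the difference is fluoro in place of hydrogen on an aromatic carbon, and the place description is the same word for word as in the earlier pair, so this is the same change made on the other core.

The expectation for compound 4 in this assay rests on the earlier step because a 1.5-fold lower number from compound 2 to compound 1 (0.18 log units; within the scatter) was small, and the core change itself also stayed small. The step from compound 3 to compound 4 is therefore expected to be about a 1.5-fold lower number from compound 3 to compound 4 (0.16 log units; within the scatter). Compound 4 is estimated to give 110 uM, with a plausible range from 60 uM to 200 uM.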

Compound 4, half-maximal toxic concentration: 90.8 uM
For compound 4 the middle estimate is 1.2-fold (0.08 log units) above the measured one, within the range that was stated.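

In this assay, the change from 4-fluorophenyl to 3,4-difluorophenyl gave a 1.8-fold lower number from compound 3 to compound 4 (0.25 log units; within the scatter), and the two cores do not differ in their response to this change: the same change on two cores in this assay, a 1.5-fold lower number (0.18 log units; within the scatter) from compound 2 to compound 1 and a 1.8-fold lower number (0.25 log units; within the scatter) from compound 3 to compound 4, 1.2-fold (0.06 log units) apart, within the scatter of two such steps

Across both differences in the sulfur-bearing group, the step is a 2.2-fold lower number from compound 2 to compound 4 (0.35 log units; beyond the scatter), which is modest and the only new step beyond the scatter, while the other new step, a 1.5-fold lower number from compound 1 to compound 4 (0.17 log units; within the scatter), stays within it. Each fluoro step alone lies within the scatter, so the result shows that this change carried over between these two cores without a detectable difference, but it does not establish an effect of the added fluoro on either core, and two cores give no basis for a rule across the wider series.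

Still open, on these data alone, is whether a chloro or methoxy group in place of the added fluoro, or a carboxylic acid or amide in place of the ethyl ester, would carry over between the two cores in the same way. Only this assay is shown, so the behaviour of this change in any other read-out also remains unknown.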